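The source may report more compounds than this note shows. Statements on the series, on what has been measured and on what is new or still open speak of the compounds shown alone.

In an ADME assay on J774 cells (Mus musculus) for cytotoxicity, read by resazurin assay, with a stated time of 24 h (on this read-out higher numbers stand for lower toxicity in this test and lower numbers for higher toxicity in this test), compound 1 `COC(=O)c1cc2nc(SCC(=O)Nc3ccc(Cl)cc3)[nH]c2cc1Cl` gives 90400 nM, and compound 2 `COC(=O)c1cc2nc(SCC(=O)Nc3nccs3)[nH]c2cc1Cl` gives 104000 nM. Among the compounds with values here, these two values lie within the scatter of each other, so compound 2 stands level with compound 1 on the numbers so far. Compound 3 `COC(=O)c1cc2nc(SCC(=O)Nc3ncc([N+](=O)[O-])s3)[nH]c2cc1Cl` keeps all of compound 2 except for one change on the ring: nitro in place of hydrogen on an aromatic carbon. This is nitro in place of hydrogen on an aromatic carbon, turning 1,3-thiazol-2-yl into 5-nitro-1,3-thiazol-2-yl. Within the data shown here, only one measured step bears on it, a 1.2-fold higher number from compound 1 to compound 2 (0.06 log units; within the scatter), where 1,3-thiazol-2-yl replaced 4-chlorophenyl on an amide-type nitrogen. Among the measured compounds shown here, that swap of a whole ring left the number within the scatter, but no measured compound carries a nitro, so it is only a weak guide. The expected change, a 1.4-fold lower number from compound 2 to compound 3 (0.14 log units; within the scatter), is no step beyond the scatter. For compound 3 the estimated value is 75000 nM, with an expected range of 25000 nM to 150000 nM.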

Compound 3, half-maximal cytotoxic concentration: 84900 nM
Compound 3: the middle estimate sits 1.1-fold (0.05 log units) below what was measured; low and high end bracket the measured number.
By their numbers in this assay, from the lowest: compounds 3, 1 and 2 (each within the scatter of the next).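

In this assay, nitro on the aromatic carbon next to the ring sulfur gives a 1.2-fold lower number from compound 2 to compound 3 (0.09 log units; within the scatter), so compound 3 stands level with compound 2 even though this change adds 3 heavy atoms to the ring. The step of a 1.1-fold lower number from compound 1 to compound 3 (0.03 log units; within the scatter) puts 5-nitro-1,3-thiazol-2-yl level with 4-chlorophenyl on the amide-type nitrogen, so all three compounds now lie within the scatter of one another. Nothing measured here gives a reason for this.

Going by these compounds, it remains open whether a different group on this same ring carbon, such as an amine or a carboxylic acid, would also stand level with hydrogen and nitro. All three compounds also share the core of compound 1, so the effect of a carboxylic acid in place of its methyl ester is open too.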